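Series notes: pyrrolidin-1-yl in place of morpholin-4-yl

The compounds below may be only part of what the source reports. "The series", "measured", "known", "first", "only" and "open" are said of these compounds alone.

Measured so far:
compound 1, `Cc1cccc(/C(N)=N/NC(=S)N2CCN(c3ccccn3)CC2)n1`, 19600 nM
compound 2, `N/C(=N\NC(=S)N1CCN(c2ccccn2)CC1)c1ccc(F)cn1`, 13400 nM
compound 3, `Cc1ccnc(/C(N)=N/NC(=S)N2CCOCC2)c1`, 6800 nM

All three numbers come from a functional assay on A-431 cells (Homo sapiens) for cytotoxicity, read by MTT assay, with a stated time of 72 h; a lower number here means a stronger inhibitor, a higher number a weaker inhibitor. Compound 3 carries the lowest number of the three. Against compound 2 the gap is within the scatter; against compound 1 it is beyond the scatter, so only that one comparison counts as a real separation. Going by the values given here, the single step recorded among measured compounds, a 1.5-fold lower number from compound 1 to compound 2 (0.17 log units; within the scatter), concerns the group on the carbon with a double bond to nitrogen and stays within the scatter.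

Compound 4 is `Cc1ccnc(/C(N)=N/NC(=S)N2CCCC2)c1`. The change from compound 3 is pyrrolidin-1-yl in place of morpholin-4-yl on a thiocarbonyl carbon. Among the compounds with values here, no measured step touches the thiocarbonyl carbon; the one recorded step, between compound 1 and compound 2, sits on the other side of the shared core and says nothing about this exchange. Within the data shown here, with no step on this position at all, and the only recorded step anywhere in the set within the scatter, the expectation for this assay is a step of no more than the usual scatter, in either direction. Compound 4 is therefore estimated at 6800 nM, between 2500 nM and 18000 nM. The expected step is no change at the digits printed from compound 3 to compound 4 (within the scatter).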

Compound 4, half-maximal inhibitory concentration: 900 nM
Compound 4: the middle estimate sits 7.6-fold (0.88 log units) above what was measured; measured number below the stated range.
By their numbers in this assay, from the lowest: compound 4; then compounds 3, 2 and 1 (each within the scatter of the next, the first and the last beyond it).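

In this assay, going by these compounds alone, the thiocarbonyl carbon proves to be a place where the group matters: pyrrolidin-1-yl in place of morpholin-4-yl gives a 7.6-fold lower number from compound 3 to compound 4 (0.88 log units; beyond the scatter), the only step that lies beyond the scatter. Within the data shown here, the earlier compounds held no step at this place, and their one recorded step, on the carbon with a double bond to nitrogen, stayed within the scatter. The exchange changes the ring size, the ring hetero atoms and the hydrogen-bond acceptor count together, and this single pair cannot separate those changes; nothing measured here accounts for the drop in the number.

Going by these compounds, whether ring size or the ring oxygen is what counts remains open, and a piperidine ring or an open dimethylamino group on the thiocarbonyl carbon would bear on that question. Also open, on these data alone, is whether a step of this size carries over to compounds with another group on the carbon with a double bond to nitrogen, such as those in compound 1 and compound 2.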